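Shortening the Ether Chain on the Core of Compound 1

This account rests on a few compounds, and the source may have more. Where it says the series, first, only, none or still open, it means among the compounds named here.

Measured compounds:
- compound 1, `CCOCc1cc(O)c(O)c(Br)c1Cc1cc(O)c(O)c(Br)c1Br`, giving 4600 nM
- compound 2, `Oc1cc(COCc2cc(O)c(O)c(Br)c2Br)c(Br)c(Br)c1O`, giving 8600 nM

Both were tested in a functional assay on BGC-823 cells (Homo sapiens) for cytotoxicity, read by MTT assay, with a stated time of 96 h; on this read-out higher numbers stand for weaker inhibition and lower numbers for stronger inhibition. Within the data shown here, of the two numbers, the one for compound 1 is the smaller, yet the gap to compound 2 falls within the usual scatter, so the two compounds cannot be told apart on this read-out. Among the measured compounds shown here, no pair of measured compounds differs in just one place, so no single step is available to learn from.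

Compound 3, `COCc1cc(O)c(O)c(Br)c1Cc1cc(O)c(O)c(Br)c1Br`, is the next case. It differs from compound 1 by hydrogen in place of methyl on a saturated chain carbon bound to an oxygen on a saturated carbon. Such a small trimming of a chain, with no change in the rest of the molecule, gives no ground to expect a shift beyond the scatter, so the step from compound 1 to compound 3 is expected to be about a 1.1-fold higher number from compound 1 to compound 3 (0.04 log units; within the scatter). Compound 3 is therefore estimated at 5000 nM, within a range from 2000 nM to 12000 nM.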

Compound 3, half-maximal inhibitory concentration: 18000 nM
The estimate for compound 3 lay 3.6-fold (0.56 log units) below the measured number, and the stated range ends below it.
By their numbers in this assay, from the lowest: compounds 1 and 2 (each within the scatter of the next); then compound 3.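

In this assay, among these compounds, the change from ethoxymethyl to methoxymethyl gives a 3.9-fold higher number from compound 1 to compound 3 (0.59 log units; beyond the scatter) and is the first single change that can be read on this core. It shows that this position responds to a small edit: losing one methyl, a single carbon with no ring and no charge, is enough to weaken inhibition on this read-out. The two earlier compounds could not show this, as they differ in more than one place. Nothing at hand says what lies behind this step.

From the compounds shown here alone, one step gives only two points along this chain, so it remains open whether a longer chain such as propoxymethyl would strengthen inhibition further. Going by these compounds, it is equally open how a hydroxymethyl group, an amine or a carboxylic acid would fare at this position.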